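Removal of the pentyl chain from a cytotoxicity lead

A few compounds are considered here, and "the series" means these few. Any claim that something is new, unique, unknown or untested is made for them only; others in the source may bear on it.

For the measured compounds named here, compound 2 `CCCCCc1ccc(C#Cc2cc3cn([C@H]4C[C@H](O)[C@@H](CO)O4)c(=O)nc3o2)cc1` is the one member of this set with a numerical read-out in an ADME assay on HEL cells (Homo sapiens) for cytotoxicity, with a stated time of 3 days; a lower number here means that less compound is tolerated, a higher number that more compound is tolerated: compound 2 gives 110000 nM. Compound 1 `CCCCCCc1cnc(-c2cc3cn([C@H]4C[C@H](O)[C@@H](CO)O4)c(=O)nc3o2)nc1` is reported in this assay only as a limit, > 50000 nM, and (the limit of > 50000 nM in this assay, at which 1 of the 2 values shown sits). No change between two measured compounds is available for comparison.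

Compound 3 `O=c1nc2oc(C#Cc3ccccc3)cc2cn1[C@H]1C[C@H](O)[C@@H](CO)O1` keeps the whole framework of compound 2 and differs in one place: hydrogen in place of pentyl on an aromatic carbon. The change takes away a chain of five carbons and puts nothing in its place.

Going by the values given here, with no measured step to lean on, the expected step in this assay is small; the estimated move a 1.4-fold higher number from compound 2 to compound 3 (0.13 log units; within the scatter) points toward somewhat more compound being tolerated, though the change may well stay within the scatter. Compound 3 is expected to give about 150000 nM in this assay, within a range from 50000 nM to 400000 nM.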

Compound 3, half-maximal cytotoxic concentration: > 570000 nM
Compound 3 ended at the assay's limit; the forecaster's own chance of this, stated with the estimate: 40%; middle value at least 3.8-fold (0.57 log units) from the limit.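

For the compounds shown here, replacing pentyl with hydrogen on the aromatic carbon para to a large group gives the first measured step at this position: in this assay the change is an at least 5.1-fold higher number from compound 2 to compound 3 (0.71 log units; beyond the scatter). In this one pair, the compound with hydrogen at this carbon is tolerated at a higher concentration than the one carrying the chain of five carbons. Compound 3 is recorded only as a limit, so the step fixes a minimum size and nothing more: the limit of > 570000 nM in this assay, at which 1 of the 3 values shown sits.

On these data alone, whether a shorter chain such as methyl or ethyl, or an amine or a hydroxyl group on the same carbon, would fall between compound 2 and compound 3 remains open. Also open, as far as these compounds go, is whether the same change would have a similar effect on the framework of compound 1, which differs from compound 2 in more than one place.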